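Halogen swap on the pyridinyl sulfonamide of compound 3

The source may report more compounds than this note shows. Statements on the series, on what has been measured and on what is new or still open speak of the compounds shown alone.

Measured so far:
Compound 1, `O=S(=O)(CSc1nnc(Br)n1Cc1ccc(Br)c2ccccc12)Nc1ccccc1`, gives 15800 nM in an assay on HEK293 cells for inhibition of solute carrier family 22 member 12 (Homo sapiens); a higher number here means a weaker inhibitor, a lower number a stronger inhibitor.
Compound 2, `O=S(=O)(CSc1nnc(Br)n1Cc1ccc(Br)c2ccccc12)Nc1ccc(F)nc1`, gives 1550 nM in this assay.
Compound 3, `O=S(=O)(CSc1nnc(Br)n1Cc1ccc(Br)c2ccccc12)Nc1cccnc1Br`, gives 280 nM in this assay.

Compound 3 holds the lowest number of the three. Its nearest neighbour is compound 2, reached by a 5.5-fold lower number from compound 2 to compound 3 (0.74 log units; beyond the scatter); its furthest is compound 1, reached by a 56-fold lower number from compound 1 to compound 3 (1.75 log units; beyond the scatter). Both steps vary only the aryl group on the sulfonamide nitrogen, and both end at the 2-bromopyridin-3-yl of compound 3. The step of a 10-fold lower number from compound 1 to compound 2 (1.01 log units; beyond the scatter) shows that a ring nitrogen alone already moves the number a long way.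

Compound 4, `O=S(=O)(CSc1nnc(Br)n1Cc1ccc(Br)c2ccccc12)Nc1cccnc1Cl`, keeps everything of compound 3 and changes one atom: chloro in place of bromo on an aromatic carbon. For the measured compounds named here, no measured pair here exchanges one halogen for another at the same position, so no step bears on it directly. The measured steps show that the aryl group on the sulfonamide nitrogen matters strongly, but they contrast phenyl, fluoropyridinyl and bromopyridinyl, not chloro against bromo. A like-for-like exchange of this kind is expected to leave the number close to that of compound 3, with any step a 1.4-fold higher number from compound 3 to compound 4 (0.15 log units; within the scatter) in this assay expected to sit within or just beyond the scatter, if anything toward a higher number.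

Compound 4 is therefore expected to give 400 nM in this assay, within 150 nM to 1200 nM.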

Compound 4, half-maximal inhibitory concentration: 5100 nM
Compound 4: middle estimate off by 13-fold (1.11 log units), on the low side; measured number outside the range, above it.
By their numbers in this assay, from the lowest: compound 3; then compound 2; then compound 4; then compound 1.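

Bromo and chloro are not interchangeable on this aromatic carbon next to the ring nitrogen: in this assay, this single-atom exchange gives an 18-fold higher number from compound 3 to compound 4 (1.26 log units; beyond the scatter) and is the only direct halogen comparison in the set. The 2-chloropyridin-3-yl group still improves on phenyl, with a 3.1-fold lower number from compound 1 to compound 4 (0.49 log units; beyond the scatter) as the step, but it falls behind 6-fluoropyridin-3-yl, with a 3.3-fold higher number from compound 2 to compound 4 (0.52 log units; beyond the scatter) as the step, so much of the advantage of compound 3 is lost once bromo is replaced. Nothing available here accounts for the size of this halogen step.

From the compounds shown here alone, whether an iodo, methyl or trifluoromethyl group on the same carbon would keep the number near that of compound 3 or move it towards that of compound 4 remains open. Also open, going by these compounds, is whether the same bromo-to-chloro exchange would give a step of similar size on a 2-halophenyl ring, without the ring nitrogen, or with the other substituents of the shared core changed.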